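Trifluoromethyl in Place of Nitro: Cytotoxicity Outlook for Compound 3

This account rests on a few compounds, and the source may have more. Where it says the series, first, only, none or still open, it means among the compounds named here.

Measured compounds:
compound 1, `O=[N+]([O-])c1ccccc1NC(CO)CO`, gives > 100000 nM in an ADME assay on MCF-10A cells (Homo sapiens) for cytotoxicity (a higher number here means a weaker inhibitor, a lower number a stronger inhibitor), a limit of the assay rather than a number.
compound 2, `O=[N+]([O-])c1ccc(NC(CO)CO)c([N+](=O)[O-])c1`, gives > 100000 nM in this assay, likewise a limit.

Both shown values rest at the same point, (the limit of > 100000 nM in this assay, at which 2 of the 2 values shown sit). The step that the two limits leave unreadable from compound 1 to compound 2 is therefore left unreadable, since neither end is a true number. Among the measured compounds shown here, compound 2 thus stands only at a limit in this assay, with no firm value to anchor it, and the one further value shown is a limit as well.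

Compound 3, `O=[N+]([O-])c1cc(C(F)(F)F)ccc1NC(CO)CO`, is not yet measured and differs from compound 2 by trifluoromethyl in place of nitro on an aromatic carbon. For the measured compounds named here, no measured step involves a trifluoromethyl group, and the single step available, a step that the two limits leave unreadable from compound 1 to compound 2, carries no readable size. Nothing in the two measured compounds points in either direction for this change.

Compound 3 is therefore expected to remain at or near the limit, with an estimate of 150000 nM in this assay, ranging from 50000 nM to 500000 nM. The expected step that the limit leaves unreadable from compound 2 to compound 3 is accordingly taken as none beyond the scatter, with a high chance that only a limit is again reported.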

Compound 3, half-maximal inhibitory concentration: > 100000 nM
Compound 3: a limit, no number (the forecaster's own chance of this, stated with the estimate: 80%); the middle value is on the limit's open side.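

Compound 3 gives > 100000 nM in this assay, again a limit of the assay and not a number. Among the compounds shown here, no step among compound 1, compound 2 and compound 3 can therefore be read, since all rest at one point: the limit of > 100000 nM in this assay, at which 3 of the 3 values shown sit. The compounds shown leave open how far past that limit each one lies, and whether hydrogen, nitro or trifluoromethyl on that aromatic carbon makes any difference.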